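The source may hold more compounds than are shown below. What is called first, only, known or untested is meant among the compounds shown, and "the series" means these compounds.

In an ADME assay on microsomes from liver (Homo sapiens) for metabolic stability, read by mass spectrometry, using NADPH, tested at 1.5 uM (a higher number here means that the compound lasts longer, a lower number that the compound disappears faster), compound 3 (`O=C(Nc1ccc2sc(-c3ccccc3)nc2c1)N1CCCC1`) gives 0.5 h. This is the higher of the two exact numbers available, the other being the 0.148 h of compound 1 (`O=C(Nc1ccc2sc(-c3cccc(F)c3)nc2c1)N1CCCCC1`), which differs from compound 3 in more than one place. Compound 2 (`O=C(Nc1ccc2sc(-c3ccc(F)c(F)c3)nc2c1)N1CCCC1`) reads > 1 h, which is a limit of the assay and not a number.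

Compound 4 (`O=C(Nc1ccc2sc(-c3cccc(F)c3)nc2c1)N1CCCC1`) keeps the frame of compound 3 and makes one change: fluoro in place of hydrogen on an aromatic carbon. Put another way, the phenyl of compound 3 becomes 3-fluorophenyl in compound 4.

Within the data shown here, only one measured step bears directly on this change. It is an at least 2.0-fold lower number from compound 2 to compound 3 (0.30 log units; that floor lies within the scatter), where phenyl replaces 3,4-difluorophenyl, and so it runs opposite to the addition of fluoro and involves a different substitution. It points weakly towards a longer half-life for compound 4 in this assay. Compound 1 carries the same 3-fluorophenyl, yet its 0.148 h is the lowest exact number, so it goes against any simple reading. A small rise, not clearly beyond the scatter, is therefore expected. The expected change is a 1.4-fold higher number from compound 3 to compound 4 (0.15 log units; within the scatter). Compound 4 is estimated at 0.7 h, with an expected range from 0.35 h to 1.4 h.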

Compound 4, half-life: 0.617 h
Compound 4: middle estimate off by 1.1-fold (0.05 log units), on the high side; low and high end bracket the measured number.
By their numbers in this assay, from the lowest: compound 1; then compounds 3 and 4 (each within the scatter of the next). At a limit, above all of these: compound 2.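

In this assay, fluoro in place of hydrogen on an aromatic carbon, meta to a large group, gives a 1.2-fold higher number from compound 3 to compound 4 (0.09 log units; within the scatter), so this single change on the phenyl does not separate compound 3 from compound 4. With the 3-fluorophenyl held the same, pyrrolidin-1-yl in place of piperidin-1-yl on a carbonyl carbon gives a 4.2-fold higher number from compound 1 to compound 4 (0.62 log units; beyond the scatter), which places the low number of compound 1 with its piperidin-1-yl and removes the conflict that its 3-fluorophenyl seemed to raise. Hydrogen in place of the second fluoro gives an at least 1.6-fold lower number from compound 2 to compound 4 (0.20 log units; that floor lies within the scatter), a floor that cannot order the two compounds, and the reading for compound 2 is a limit of the assay and not a number: the limit of > 1 h in this assay, at which 1 of the 4 values shown sits.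

On these data alone, how far compound 2 truly lies from compound 4 therefore stays open, and with it whether the 3,4-difluorophenyl adds anything to the 3-fluorophenyl. Also open, as far as these compounds go, is how a chloro or a methoxy at the same place on the phenyl would read, and how a morpholin-4-yl or an azetidin-1-yl on the carbonyl carbon would compare with the pyrrolidin-1-yl.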